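The source may hold more compounds than are shown below. What is called first, only, known or untested is meant among the compounds shown, and "the series" means these compounds.

Measured so far:
compound 1 (`N#Cc1ccc(-c2nc(NCCNc3ccc([N+](=O)[O-])c(N)n3)ncc2-c2ncc[nH]2)cc1`) with > 0.5 h
compound 2 (`N#Cc1ccc(NCCNc2ncc(-c3ncc[nH]3)c(-c3ccc(Cl)cc3Cl)n2)nc1`) with > 0.5 h

In an ADME assay on microsomes from liver (Canis lupus familiaris) for metabolic stability (on this read-out higher numbers stand for a longer-lived compound and lower numbers for a shorter-lived compound), compound 1 stands at > 0.5 h as its reading, which is a limit of the assay and not a number. Compound 2 gives > 0.5 h as its reading, and this too is only a limit. The whole record so far is therefore one boundary (the limit of > 0.5 h in this assay, at which 2 of the 2 values shown sit), and neither compound has a true number.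

Compound 3 (`Nc1nc(NCCNc2ncc(-c3ncc[nH]3)c(-c3ccccc3Cl)n2)ccc1[N+](=O)[O-]`) has not yet been measured. It departs from compound 1 in one place, with 2-chlorophenyl in place of 4-cyanophenyl on an aromatic carbon. That carbon belongs to a six-membered aromatic ring with 2 nitrogen and lies ortho to a 1H-imidazol-2-yl group.

For the measured compounds named here, no step between measured compounds is available to set a size, so no shift beyond the usual scatter is expected in this assay. The expected change is a step that the limit leaves unreadable from compound 1 to compound 3 in this reading. For compound 3 the estimated half-life is 0.6 h with an expected range from 0.3 h to 1.2 h around it, and a reading at the same limit is the likeliest report.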

Compound 3, half-life: > 0.5 h
Compound 3 gave a limit, no number; the forecaster's own chance of this, stated with the estimate: 70%; the middle value lies beyond the limit too.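

In this assay compound 3 gives > 0.5 h, a limit and not a number. Compound 1 also stands at a limit, so no step can be read between compound 1 and compound 3. The compounds shown leave open the true half-life of each, and whether 2-chlorophenyl in place of 4-cyanophenyl changes it at all: the limit of > 0.5 h in this assay, at which 3 of the 3 values shown sit.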